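The source may report more compounds than this note shows. Statements on the series, on what has been measured and on what is new or still open speak of the compounds shown alone.

Working notes on the solubility series. In a physicochemical assay for solubility, read by LC-MS, in phosphate buffer, measured as kinetic solubility, with a stated time of 24 h, at 25 degrees C, at pH 7.4 (a higher number here means a more soluble compound, a lower number a less soluble compound), compound 1 `Nc1cc(-c2ccc3cn[nH]c3c2)nc(N)n1` gives 660000 nM, compound 2 `Nc1nccc(-c2ccc3c(NCc4ccccc4)n[nH]c3c2)n1` gives 17000 nM, and compound 3 `CC(C)(C)Oc1cc(-c2ccnc(N)n2)cc2[nH]nc(N)c12` gives 68000 nM. On these three numbers compound 3 stands second highest: below compound 1 and above compound 2, with both gaps beyond the scatter.

The next compound, compound 4 `Nc1nccc(-c2cc(Oc3ccccc3)c3c(N)n[nH]c3c2)n1`, differs from compound 3 in one place: phenyl in place of tert-butyl on an oxygen on an aromatic ring. Among the compounds with values here, no measured pair in this set shows the same change, so the size of its effect on this assay is not known from the data; the step from compound 3 to compound 4 is expected to be a decrease of modest size, a 2.7-fold lower number from compound 3 to compound 4 (0.43 log units; beyond the scatter), somewhat beyond the scatter.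

In this assay compound 4 is therefore estimated at 25000 nM, with a range of 8000 nM to 80000 nM.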

Compound 4, solubility: 117000 nM
Estimate against measurement, compound 4: 4.7-fold (0.67 log units) below, outside the stated range (above it).
By their numbers in this assay, from the lowest: compound 2; then compounds 3 and 4 (each within the scatter of the next); then compound 1.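

Within the data shown here, this is the first pair that differs in one place. In this assay, phenyl in place of tert-butyl on an oxygen on an aromatic ring gives a 1.7-fold higher number from compound 3 to compound 4 (0.24 log units; within the scatter), so this change leaves the two compounds indistinguishable on this read-out, despite the added aromatic ring. The data shown offer no measurement that would explain this result.

Still open, on these data alone, is whether a group carrying an amine or a carboxylic acid on that oxygen would shift the number beyond the scatter. As far as these compounds go, whether the same change behaves alike on another core also remains unknown.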